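The compounds below may be only part of what the source reports. "The series", "measured", "known", "first", "only" and "open" are said of these compounds alone.

Series: compound 1 `CCCC(=O)Nc1ccc(-c2cn3c(=O)c(C(=O)OCC)cn(Cc4ccccc4F)c3n2)cc1`, compound 2 `CCCC(=O)Nc1ccc(-c2cn3c(=O)c(C(=O)OC(CC)CC)cn(Cc4ccccc4F)c3n2)cc1`, compound 3 `CCCC(=O)Nc1ccc(-c2nc3n(Cc4ccccc4F)cc(C(=O)OCC)c(=O)n3c2CN(C)Cc2ccccc2)cc1` and, not yet measured, compound 4 `CCCC(=O)Nc1ccc(-c2nc3n(Cc4ccccc4F)cc(C(=O)OC(CC)CC)c(=O)n3c2CN(C)Cc2ccco2)cc1`. In an assay on isolated protein for agonist activity at Gonadotropin-releasing hormone receptor (Homo sapiens) (on this read-out higher numbers stand for weaker inhibition and lower numbers for stronger inhibition), compound 1 gives 30000 nM, compound 2 gives 28000 nM and compound 3 gives 80 nM. Compound 2 stands second highest of the three numbers: against compound 1 the step of a 1.1-fold lower number from compound 1 to compound 2 (0.03 log units; within the scatter) is within the scatter, while the number of compound 3 lies far below it, beyond the scatter. The change to compound 4 is (((furan-2-yl)methyl)(methyl)amino)methyl in place of hydrogen on an aromatic carbon. The step that bears on it is a 380-fold lower number from compound 1 to compound 3 (2.57 log units; beyond the scatter), the same kind of substituent on the same carbon; the other measured step, a 1.1-fold lower number from compound 1 to compound 2 (0.03 log units; within the scatter), stayed within the scatter. For compound 4 a drop of similar size is therefore expected, a 280-fold lower number from compound 2 to compound 4 (2.45 log units; beyond the scatter). Compound 4 is estimated at 100 nM, range 30 nM to 400 nM.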

Compound 4, inhibition constant: 29 nM
Estimate against measurement, compound 4: 3.4-fold (0.54 log units) above; measured number below the stated range.
By their numbers in this assay, from the lowest: compound 4; then compound 3; then compounds 2 and 1 (each within the scatter of the next).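

In this assay the (((furan-2-yl)methyl)(methyl)amino)methyl group on this aromatic carbon gives a 970-fold lower number from compound 2 to compound 4 (2.98 log units; beyond the scatter) on the pentan-3-yl ester. Together with a 380-fold lower number from compound 1 to compound 3 (2.57 log units; beyond the scatter) on the ethyl ester, this shows that the large drop at this position is not tied to one ester or to a benzyl group on the amine. No measurement shown accounts for the gain.

Compound 3 and compound 4 differ in two places, so the furan-2-yl and benzyl groups cannot be ranked against each other. On these data alone, whether a ring on the amine is needed remains open, and a plain dimethylaminomethyl group on this carbon would address that.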